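The source may hold more compounds than are shown below. What is called first, only, known or untested is meant among the compounds shown, and "the series" means these compounds.

Measured compounds:
compound 1 `COc1ccc(NC(=O)CSC(=S)N[C@H]2CCOC2=O)cc1` — > 128000 nM
compound 2 `O=C(CSC(=S)N[C@H]1CCOC1=O)Nc1cccc(C(F)(F)F)c1` — 3130 nM

In a functional assay on MCF7 cells (Homo sapiens) for cytotoxicity, read by MTT assay, with a stated time of 72 h (on this read-out lower numbers stand for stronger inhibition and higher numbers for weaker inhibition), compound 1 is reported only as a limit, > 128000 nM; it sits at the limit of > 128000 nM in this assay, at which 1 of the 2 values shown sits. Compound 2 gives 3130 nM in this assay. Going by the values given here, no step between measured compounds is available. Compound 3 `O=C(CSC(=S)N[C@H]1CCOC1=O)Nc1ccc(C(=O)/C=C/c2ccccc2)cc1` differs from compound 1 in one place: (2-phenylethenyl)carbonyl in place of methoxy on an aromatic carbon. A step towards stronger inhibition is expected, of the size an at least 10-fold lower number from compound 1 to compound 3 (1.02 log units; beyond the scatter), because compound 1 stands at the limit of > 128000 nM in this assay, at which 1 of the 2 values shown sits, and only a lower number can be read. Compound 3 is estimated at 12000 nM in this assay, within 1500 nM to 80000 nM.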

Compound 3, half-maximal inhibitory concentration: 44300 nM
Compound 3: the middle estimate sits 3.7-fold (0.57 log units) below what was measured; the measured number falls inside the stated range.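

In this assay, going by these compounds alone, (2-phenylethenyl)carbonyl in place of methoxy on this aromatic carbon, para to a large group, gives an at least 2.8-fold lower number from compound 1 to compound 3 (0.46 log units; beyond the scatter), the first step that can be read at this position. The true size of this step remains unknown because the value for compound 1 is a limit: the limit of > 128000 nM in this assay, at which 1 of the 3 values shown sits.

The compounds shown do not separate the contributions of the carbonyl, the double bond and the added aromatic ring to this step. From the compounds shown here alone, how an amine, a carboxylic acid or a saturated 3-phenylpropanoyl group would read at this position also remains open.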